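The source may report more compounds than this note shows. Statements on the series, on what has been measured and on what is new or still open speak of the compounds shown alone.

Of the compounds shown here, two have been measured in an assay on cells for inhibition of MAP kinase-interacting serine/threonine-protein kinase 1 (Homo sapiens), read by mobility shift assay, with stated times of 10 min and 60 min, in the presence of a further agent that is not named here; a higher number here means a weaker inhibitor, a lower number a stronger inhibitor. Compound 1 `NC(=O)c1ccc(-c2cccnc2)cc1O` gives 4300 nM. Compound 2 `CC(C)Oc1cc(-c2cncc(-c3nn[nH]n3)c2)ccc1C(N)=O` gives 310 nM, the lowest of the two numbers; compound 1 sits well beyond the scatter from it. Compound 3 `CC(C)Oc1cc(-c2cccnc2)ccc1C(N)=O` has not been measured. Its structure differs from compound 2 in one place: hydrogen in place of 2H-tetrazol-5-yl on an aromatic carbon. Since compound 1, which also carries hydrogen in that place, gives 4300 nM, a weakening step is expected here, so compound 3 is estimated to give 1500 nM, in the range 500 nM to 5000 nM. That expectation means a step of a 4.8-fold higher number from compound 2 to compound 3 (0.68 log units; beyond the scatter) in this assay.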

Compound 3, half-maximal inhibitory concentration: 880 nM
The estimate for compound 3 lay 1.7-fold (0.23 log units) above the measured number; the measured number falls inside the stated range.
By their numbers in this assay, from the lowest: compound 2; then compound 3; then compound 1.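

In this assay, replacing 2H-tetrazol-5-yl with hydrogen gives a 2.8-fold higher number from compound 2 to compound 3 (0.45 log units; beyond the scatter), so this group on the aromatic carbon helps but is not essential for inhibition. Isopropyl in place of hydrogen on the oxygen separately gives a 4.9-fold lower number from compound 1 to compound 3 (0.69 log units; beyond the scatter), so part of the difference between compound 1 and compound 2 belongs to each of the two places. Nothing available explains either step. As far as these compounds go, whether a carboxylic acid or an amine on that aromatic carbon would match 2H-tetrazol-5-yl remains open. So does whether 2H-tetrazol-5-yl gives a similar step when the oxygen carries hydrogen instead of isopropyl.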